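A few compounds are considered here, and "the series" means these few. Any claim that something is new, unique, unknown or untested is made for them only; others in the source may bear on it.

In a functional assay on P388 cells (Mus musculus) for cytotoxicity (on this read-out higher numbers stand for weaker inhibition and lower numbers for stronger inhibition), three compounds on a shared core have been measured. Compound 1 `Cc1cc(-c2c(F)cc3c(=O)c(Cc4c(O)cccc4O)cn(C4CC4)c3c2F)cc(C)n1` gives 250 nM and compound 3 `Cc1cc(-c2c(F)cc3c(=O)c(Cc4c(O)cc(O)cc4O)cn(C4CC4)c3c2F)cc(C)n1` gives 470 nM with the gap between them (a 1.9-fold higher number from compound 1 to compound 3 (0.27 log units; within the scatter)) inside the scatter. Compound 2 `Cc1cc(-c2c(F)cc3c(=O)c(Cc4ccccc4)cn(C4CC4)c3c2F)cc(C)n1` gives 7300 nM and stands highest of the three, with large steps separating it from both others (a 29-fold higher number from compound 1 to compound 2 (1.47 log units; beyond the scatter)) and (a 16-fold lower number from compound 2 to compound 3 (1.19 log units; beyond the scatter)).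

The change now in view leads to compound 4 `Cc1cc(-c2c(F)cc3c(=O)c(Cc4c[nH]cn4)cn(C4CC4)c3c2F)cc(C)n1`: 1H-imidazol-4-yl in place of phenyl on a saturated chain carbon bound to an aromatic carbon. Only the two large steps bear on this, since both exchange the phenyl of compound 2 at that same place. For the measured compounds named here, they involve hydroxylated phenyl rings, however, and no measured compound carries 1H-imidazol-4-yl, so they are a loose guide to direction and a poor guide to size. Since compound 3 sits well under compound 2 (a 16-fold lower number from compound 2 to compound 3 (1.19 log units; beyond the scatter)) a move toward a lower number is expected, though a much smaller one. The expected step (a 2.4-fold lower number from compound 2 to compound 4 (0.39 log units; beyond the scatter)) is therefore modest. For compound 4 the estimate is 3000 nM with a range of 700 nM to 10000 nM expected for the measurement.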

Compound 4, half-maximal inhibitory concentration: 390 nM
For compound 4 the middle estimate is 7.7-fold (0.89 log units) above the measured one, outside the stated range (below it).
By their numbers in this assay, from the lowest: compounds 1, 4 and 3 (each within the scatter of the next); then compound 2.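

In this assay, the result shows that the large drop from the benzyl compound at this place, on a saturated chain carbon bound to an aromatic carbon, does not depend on a hydroxylated phenyl ring: a 19-fold lower number from compound 2 to compound 4 (1.27 log units; beyond the scatter) comes with (1H-imidazol-4-yl)methyl, which has one five-membered aromatic ring with 2 hetero atoms and no hydroxy group. Compound 4 cannot be told apart from the two hydroxylated compounds, with a 1.2-fold lower number from compound 3 to compound 4 (0.08 log units; within the scatter) and a 1.6-fold higher number from compound 1 to compound 4 (0.19 log units; within the scatter) both inside the scatter, so three different rings now read alike and the unsubstituted phenyl of compound 2 alone stands apart. Nothing in the information at hand accounts for the size of this step or for the likeness of the three rings.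

The compounds shown leave open whether a ring is needed at this place at all, since they do not tell how a simple amine or a carboxylic acid on the same chain carbon would read. They also leave open how a longer chain carrying the 1H-imidazol-4-yl, or a 1-methyl-1H-imidazol-4-yl group, would compare with compound 4.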